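Adding Fluorines to the Benzyl Group of Compound 1

A few compounds are considered here, and "the series" means these few. Any claim that something is new, unique, unknown or untested is made for them only; others in the source may bear on it.

Within the data shown here, compound 1, `OC[C@H]1O[C@@H](n2cnc3c(NCc4cccc(F)c4)ncnc32)[C@H](O)[C@@H]1O`, is the only member of this small set with a definite number: in a functional assay on CCRF-CEM cells (Homo sapiens) for antiproliferative activity, with a stated time of 72 h (a lower number here means a stronger inhibitor, a higher number a weaker inhibitor), compound 1 gives 4000 nM. Compound 2, `COc1cccc(CNc2ncnc3c2ncn3[C@@H]2O[C@H](CO)[C@@H](O)[C@H]2O)c1OC`, reaches only a limit of this assay, > 166000 nM. Compound 3, `COc1ccc(CNc2ncnc3c2ncn3[C@@H]2O[C@H](CO)[C@@H](O)[C@H]2O)c(OC)c1`, likewise stops at a limit, > 166000 nM. Both steps away from compound 1 are therefore large: an at least 41-fold higher number from compound 1 to compound 2 (1.61 log units; beyond the scatter), and an at least 41-fold higher number from compound 1 to compound 3 (1.61 log units; beyond the scatter). Between compound 2 and compound 3 the two limits leave the step unreadable, a step that the two limits leave unreadable from compound 2 to compound 3. The shared picture is that the limit of > 166000 nM in this assay, at which 2 of the 3 values shown sit, is where the dimethoxy compounds end up.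

Compound 4, `OC[C@H]1O[C@@H](n2cnc3c(NCc4c(F)ccc(F)c4F)ncnc32)[C@H](O)[C@@H]1O`, differs from compound 1 in a different way: 2,3,6-trifluorophenyl in place of 3-fluorophenyl on a saturated chain carbon bound to a nitrogen on an aromatic ring. The measured steps both concern methoxy groups entering, whereas here fluorine is kept and two more fluorines join it, so they bear on compound 4 only loosely. Compound 4 is expected to land in the same region as compound 1, with a step of a 1.5-fold higher number from compound 1 to compound 4 (0.18 log units; within the scatter) that may fall inside the scatter or slightly beyond it. The estimate for compound 4 in this assay is 6000 nM, with a range from 1500 nM to 30000 nM.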

Compound 4, half-maximal inhibitory concentration: 90300 nM
For compound 4 the middle estimate is 15-fold (1.18 log units) below the measured one; the measured number lies above the stated range.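

Compound 4 shows that the drop in activity at this place, on a saturated chain carbon bound to a nitrogen on an aromatic ring, does not require methoxy groups: in this assay, keeping the 3-fluorine position filled and adding two further fluorines as 2,3,6-trifluorophenyl gives a 23-fold higher number from compound 1 to compound 4 (1.35 log units; beyond the scatter). Set against the two dimethoxyphenyl groups, the 2,3,6-trifluorophenyl group gives an at least 1.8-fold lower number from compound 3 to compound 4 (0.26 log units; that floor lies within the scatter) and an at least 1.8-fold lower number from compound 2 to compound 4 (0.26 log units; that floor lies within the scatter), so these floors do not establish a real order among the three weak compounds. Compound 2 and compound 3 each still stand at a limit of the assay rather than at a number: the limit of > 166000 nM in this assay, at which 2 of the 4 values shown sit.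

With only one monofluoro and one trifluoro compound, the data cannot separate the effect of the number of fluorines from the effect of where they sit on the phenyl ring. Also open, as far as these compounds go, is how this place responds to a chlorine, a nitrile or an amine on the phenyl ring, or to a longer chain in place of the single carbon that carries the ring.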